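Replacing Fluoro with Acetamido: What to Expect

The source may hold more compounds than are shown below. What is called first, only, known or untested is meant among the compounds shown, and "the series" means these compounds.

Measured in an ADME assay on L02 cells (Homo sapiens) for cytotoxicity, read by MTT assay, with a stated time of 24 h; a higher number here means a weaker inhibitor, a lower number a stronger inhibitor:
compound 1 `COc1cc(/C=C2\CN(S(=O)(=O)c3ccc(F)cc3)C/C(=C\c3ccccc3F)C2=O)cc(OC)c1`: 18500 nM
compound 2 `COc1cc(/C=C2\CN(S(=O)(=O)c3ccc(F)cc3)C/C(=C\c3cc(OC)c(OC)c(OC)c3)C2=O)cc(OC)c1`: 12300 nM

In this assay compound 2 gives 12300 nM, level with compound 1 once scatter is allowed for. Compound 3 `COc1cc(/C=C2\CN(S(=O)(=O)c3ccc(NC(C)=O)cc3)C/C(=C\c3cc(OC)c(OC)c(OC)c3)C2=O)cc(OC)c1` differs from compound 2 by acetamido in place of fluoro on an aromatic carbon. Within the data shown here, the only measured step, a 1.5-fold lower number from compound 1 to compound 2 (0.18 log units; within the scatter), changes a different group, so it bears only loosely on this one, and no measured step touches this position. No change beyond the scatter is therefore expected in this assay, though the uncertainty is wide. The expected result is a 1.1-fold higher number from compound 2 to compound 3 (0.06 log units; within the scatter). For compound 3 the estimated value is 14000 nM, with an expected range of 6000 nM to 32000 nM.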

Compound 3, half-maximal inhibitory concentration: 15900 nM
Estimate against measurement, compound 3: 1.1-fold (0.06 log units) below; measured number inside the range.
By their numbers in this assay, from the lowest: compounds 2, 3 and 1 (each within the scatter of the next).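

In this assay, the change from 4-fluorophenyl to 4-acetamidophenyl gives a 1.3-fold higher number from compound 2 to compound 3 (0.11 log units; within the scatter). Among these compounds, this is the first view of this position, and it shows that the read-out does not separate fluoro from acetamido, even though acetamido brings a hydrogen-bond donor and acceptor that fluoro lacks. Nothing available explains why the two stay level. Still open, on these data alone, is whether an amine, a carboxylic acid or a longer amide chain at this position would also stay level. As far as these compounds go, it is also open whether acetamido would do so alongside the 2-fluorophenyl of compound 1.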